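The compounds below may be only part of what the source reports. "The series", "measured", "known", "first", "only" and "open" are said of these compounds alone.

Measured compounds:
- compound 1 `FC(F)(F)c1ccc(-c2csc(N3N=C(c4ccc(Br)cc4)CC3c3cccs3)n2)cc1` gives 7810 nM in a functional assay on MCF7 cells (Homo sapiens) for antiproliferative activity, read by MTT assay, with a stated time of 48 h; a lower number here means a stronger inhibitor, a higher number a weaker inhibitor
- compound 2 `Clc1ccc(C2=NN(c3nc(-c4ccc(Br)cc4)cs3)C(c3cccs3)C2)cc1` gives 14700 nM in this assay

Of the two numbers recorded so far in this assay, compound 2 has the higher one, and its nearest neighbour is compound 1, whose number is lower by an amount that stays within the scatter of the measurement. On these two values alone, therefore, neither compound can be called the stronger inhibitor; they are best read as equivalent.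

Compound 3 `FC(F)(F)c1ccc(-c2csc(N3N=C(c4ccc(Cl)cc4)CC3c3cccs3)n2)cc1` has not yet been measured in this assay. It differs from compound 2 in one place: trifluoromethyl in place of bromo on an aromatic carbon, in words, trifluoromethyl in place of bromo on an aromatic carbon. For the measured compounds named here, no measured pair shows this exact change, so the size of the step must be expected rather than read off. Because compound 1 gives 7810 nM with a trifluoromethyl on the same kind of aryl, the expectation is that the step of a 1.5-fold lower number from compound 2 to compound 3 (0.17 log units; within the scatter) stays within the scatter, with at most a slight lean toward a lower number. Compound 3 is accordingly estimated at 10000 nM, with a range from 4000 nM to 25000 nM.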

Compound 3, half-maximal inhibitory concentration: 160 nM
The estimate for compound 3 lay 63-fold (1.80 log units) above the measured number, and the stated range ends above it.
By their numbers in this assay, from the lowest: compound 3; then compounds 1 and 2 (each within the scatter of the next).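

Compound 3 shows that this position is far from indifferent to its substituent: in this assay, with chloro held on the other aryl ring, replacing 4-bromophenyl with 4-(trifluoromethyl)phenyl gives a 92-fold lower number from compound 2 to compound 3 (1.96 log units; beyond the scatter). The second single-site comparison shows that the other aryl position matters just as much, since with trifluoromethyl held in place, chloro in place of bromo gives a 49-fold lower number from compound 1 to compound 3 (1.69 log units; beyond the scatter), so neither substituent alone accounts for the gain, and the favourable result is seen only where trifluoromethyl and chloro occur together. No measurement here explains why either change has so large an effect.

As far as these compounds go, each step has been read in only one setting, so it remains open whether trifluoromethyl would bring a comparable gain with bromo on the other ring, or whether the two changes depend on each other. From the compounds shown here alone, it is also open whether a methoxy, a nitrile or an amine at the position held by trifluoromethyl would retain the number of compound 3, and whether the thiophene is needed for it.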